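Moving the hydroxyl on a trisubstituted pyridine scaffold

The source may report more compounds than this note shows. Statements on the series, on what has been measured and on what is new or still open speak of the compounds shown alone.

Compound 2 `Oc1ccc(-c2cc(-c3ccncc3)nc(-c3ccc(Cl)cc3)c2)cc1` gives 5.9% in an assay on isolated protein for inhibition of DNA topoisomerase 1 (Homo sapiens), with a stated time of 30 min, tested at 100 uM; on this read-out higher numbers stand for a stronger effect at the one concentration tested and lower numbers for a weaker effect. Compound 1 `Oc1cccc(-c2cc(-c3ccc(Cl)cc3)nc(-c3ccsc3)c2)c1` gives 11.7% and compound 3 `Oc1ccc(-c2cc(-c3ccc(Cl)cc3)nc(-c3ccccn3)c2)cc1` gives 12.7%; both of these numbers sit within the scatter of compound 2. Among the measured compounds shown here, the only measured step, a number 6.8 percentage points higher from compound 2 to compound 3 (within the scatter), concerns a different part of the shared core and does not bear on the change to compound 4 `Oc1cccc(-c2cc(-c3ccncc3)nc(-c3ccc(Cl)cc3)c2)c1`, which is 3-hydroxyphenyl in place of 4-hydroxyphenyl on an aromatic carbon. For the measured compounds named here, compound 1 also carries 3-hydroxyphenyl but differs from compound 2 in a second place as well, so no measured step isolates this change. The step of a number 2.1 percentage points higher from compound 2 to compound 4 (within the scatter) is therefore expected to stay within the scatter. Compound 4 is estimated to give 8%, between 0% and 20% in this assay.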

Compound 4, a percentage reported as inhibition, at one concentration (the size of the read-out at that concentration, not a potency): 8%
Compound 4: the middle estimate sits on the measured number at the digits printed, within the range that was stated.
By their numbers in this assay, from the lowest: compounds 2, 4, 1 and 3 (each within the scatter of the next).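

In this assay, the swap of 4-hydroxyphenyl for 3-hydroxyphenyl opposite the ring nitrogen can now be read on its own, and the two placements of the hydroxyl are not told apart (a number 2.1 percentage points higher from compound 2 to compound 4 (within the scatter)). With 3-hydroxyphenyl held fixed, pyridin-4-yl in place of thiophen-3-yl does not separate the compounds either (a number 3.7 percentage points lower from compound 1 to compound 4 (within the scatter)). Nothing available gives a reason for these readings. The compounds shown leave open what an amine, a carboxylic acid or a methoxy group would give at this position, and whether any change here reaches beyond the scatter.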